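A few compounds are considered here, and "the series" means these few. Any claim that something is new, unique, unknown or untested is made for them only; others in the source may bear on it.

Measured in a functional assay on HCT-116 cells (Homo sapiens) for inhibition, read by CCK-8 assay, with a stated time of 72 h, tested at 2 uM; a lower number here means less inhibition of growth, a higher number more inhibition of growth at the concentration tested:
- compound 1 `COc1ccc(SCc2ccc(/C=C/C(=O)Nc3ccccc3N)cc2)cc1OC`: 12.9%
- compound 2 `Cc1ccc(SCc2ccc(C(=O)Nc3ccccc3N)cc2)cc1`: 74.8%
- compound 3 `CC(C)(C)c1ccc(SCc2ccc(/C=C/C(=O)Nc3ccccc3N)cc2)cc1`: 6.66%

Compound 2 stands highest of the three, with compound 1 and compound 3 both lower by more than the usual scatter. Compound 4 `Nc1ccccc1NC(=O)c1ccc(CSc2ccc(Cl)cc2)cc1` differs from compound 2 as follows: chloro in place of methyl on an aromatic carbon. In short, 4-methylphenyl becomes 4-chlorophenyl. For the measured compounds named here, the only measured step that changes a group on the sulfur is a number 6.2 percentage points lower from compound 1 to compound 3 (within the scatter). That pair has a different core from compound 2 and sits at low numbers, so it is only a weak guide. No step beyond the scatter is therefore expected. The estimated change is a number 2.8 percentage points lower from compound 2 to compound 4 (within the scatter). For compound 4 the expected value is 72%, with an estimated range of 50% to 88%.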

Compound 4, percent growth inhibition at one concentration: 17.5%
For compound 4 the middle estimate is 54.5 percentage points above the measured one, and the stated range ends above it.
By their numbers in this assay, from the lowest: compounds 3, 1 and 4 (each within the scatter of the next, the first and the last beyond it); then compound 2.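

Changing 4-methylphenyl to 4-chlorophenyl gives a number 57.3 percentage points lower from compound 2 to compound 4 (beyond the scatter) in this assay and so shows that this place on the ring can matter a great deal, even though one heavy atom simply replaces another and no ring, donor or acceptor enters or leaves. The earlier compounds shown here showed no step beyond the scatter for a change on the sulfur. Nothing shown here gives a measured reason for this drop.

Still open, on these data alone, is whether methyl is unusual at this place or chloro is, which fluoro, bromo or an amine on the core of compound 2 could help to settle. Also open, as far as these compounds go, is whether the same swap would have a similar effect on the core of compound 1.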